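Compound 3 to compound 4: one group exchanged

The source may report more compounds than this note shows. Statements on the series, on what has been measured and on what is new or still open speak of the compounds shown alone.

compound 1 `COc1cc(-c2ccnc3cc(-c4cccc(C#N)c4)nn23)cc(OC)c1OC` gives > 10000 nM (a limit)
compound 2 `COc1cc(-c2ccnc3cc(-c4ccc(C(F)(F)F)cc4)nn23)cc(OC)c1OC` gives 1860 nM
compound 3 `COc1cc(-c2ccnc3cc(-c4cn(C)c5ccccc45)nn23)cc(OC)c1OC` gives 762 nM

These values come from a functional assay on HCT-116 cells (Homo sapiens) for inhibition, read by CCK-8 assay, with a stated time of 48 h (on this read-out higher numbers stand for weaker inhibition and lower numbers for stronger inhibition), and the three compounds differ in one group on the shared core. Compound 1 reads > 10000 nM as a limit of the assay and not as a number. In this assay compound 3 gives 762 nM and is the strongest inhibitor of the three, with compound 2 the nearest at 1860 nM on this scale.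

Compound 4 `COc1cc(-c2ccnc3cc(-c4ccc(N(C)C)cc4)nn23)cc(OC)c1OC` carries the change 4-(dimethylamino)phenyl in place of 1-methyl-1H-indol-3-yl on an aromatic carbon and so has 4-(dimethylamino)phenyl in place of 1-methyl-1H-indol-3-yl on an aromatic carbon. Both measured compounds with a substituted phenyl group at this place lie higher than compound 3: a 2.4-fold lower number from compound 2 to compound 3 (0.39 log units; beyond the scatter) is modest and an at least 13-fold lower number from compound 1 to compound 3 (1.11 log units; beyond the scatter) is large. The step of an at least 5.3-fold lower number from compound 1 to compound 2 (0.73 log units; beyond the scatter) shows how far apart two phenyl groups can lie, so the range must stay wide.

A modest step to a higher number is therefore expected in this assay and is estimated as a 2.2-fold higher number from compound 3 to compound 4 (0.35 log units; beyond the scatter) for this change. The estimated value for compound 4 is 1700 nM within an expected range of 500 nM to 6000 nM in this assay.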

Compound 4, half-maximal inhibitory concentration: 2050 nM
Compound 4: middle estimate off by 1.2-fold (0.08 log units), on the low side, and the stated range covers the measured number.
By their numbers in this assay, from the lowest: compound 3; then compounds 2 and 4 (each within the scatter of the next). At a limit, above all of these: compound 1.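

In this assay, exchanging the 1-methyl-1H-indol-3-yl group for 4-(dimethylamino)phenyl gives a 2.7-fold higher number from compound 3 to compound 4 (0.43 log units; beyond the scatter), so a second phenyl group carrying a single substituent also fails to reach the value of the indole compound. Exchanging trifluoromethyl for dimethylamino on the phenyl ring gives a 1.1-fold higher number from compound 2 to compound 4 (0.04 log units; within the scatter), which lies within the scatter, so this assay does not separate these two substituents at this place, and compound 3 stays lower than both compounds. Compound 1 stands at a limit of the assay and not at a number, so an at least 4.8-fold lower number from compound 1 to compound 4 (0.68 log units; beyond the scatter) gives only a bound on the gap: the limit of > 10000 nM in this assay, at which 1 of the 4 values shown sits.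

The compounds shown leave open whether the lower number of compound 3 depends on the whole fused indole group or also on the methyl on its ring nitrogen, which an indol-3-yl group without that methyl would test. Compound 1 also differs from compound 4 in both its substituent and where that substituent sits on the phenyl ring, and a 4-cyanophenyl group would help to separate those two changes.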